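Para substituent of the benzyl group: hydroxy for chloro

The source may report more compounds than this note shows. Statements on the series, on what has been measured and on what is new or still open speak of the compounds shown alone.

Measured compounds:
compound 1, `COc1cc(Oc2cccc(Nc3ccccc3)c2)cc(OC)c1CNCc1ccccc1`: 3340 nM
compound 2, `COc1cc(Oc2cccc(Nc3ccccc3)c2)cc(OC)c1CNCc1ccc(F)cc1`: 2750 nM
compound 3, `COc1cc(Oc2cccc(Nc3ccccc3)c2)cc(OC)c1CNCc1ccc(Cl)cc1`: 3350 nM

All three share one core and differ only at the para position of the benzyl ring. In a functional assay on HT-29 cells (Homo sapiens) for inhibition, read by MTT assay, with a stated time of 72 h (a higher number here means a weaker inhibitor, a lower number a stronger inhibitor), the three numbers sit close together. Compound 3 is separated from compound 1 by a 1.0-fold higher number from compound 1 to compound 3 (0.00 log units; within the scatter) and from compound 2 by a 1.2-fold higher number from compound 2 to compound 3 (0.09 log units; within the scatter); fluoro in place of hydrogen gives a 1.2-fold lower number from compound 1 to compound 2 (0.08 log units; within the scatter). None of these steps leaves the scatter, so the measured set gives no sign that a halogen at this position moves the number in either direction.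

Compound 4, `COc1cc(Oc2cccc(Nc3ccccc3)c2)cc(OC)c1CNCc1ccc(O)cc1`, takes the next step from compound 3: hydroxy in place of chloro on an aromatic carbon. Among the measured compounds shown here, the steps that bear on it are the two halogen exchanges above, both flat. For the measured compounds named here, no compound with a hydrogen-bond donor or acceptor at this position has been measured, so the hydroxy group is a step into unmeasured ground, and the flat halogen steps are the only guide. The expected step in this assay is therefore none beyond the scatter, a 1.0-fold lower number from compound 3 to compound 4 (0.01 log units; within the scatter), with a wider range than usual to allow for the new group. Compound 4 is expected to give 3300 nM, between 1400 nM and 8000 nM.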

Compound 4, half-maximal inhibitory concentration: 2180 nM
Estimate against measurement, compound 4: 1.5-fold (0.18 log units) above, within the range that was stated.
By their numbers in this assay, from the lowest: compounds 4, 2, 1 and 3 (each within the scatter of the next).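

In this assay, among the compounds shown here, the hydroxy group is the only group of the four at this position with a hydrogen-bond donor and a hydrogen-bond acceptor, yet every step to it stays within the scatter (a 1.5-fold lower number from compound 3 to compound 4 (0.19 log units; within the scatter)) (a 1.3-fold lower number from compound 2 to compound 4 (0.10 log units; within the scatter)) (a 1.5-fold lower number from compound 1 to compound 4 (0.19 log units; within the scatter)). The flat picture seen with hydrogen, fluoro and chloro on this aromatic carbon therefore also holds for a group of a different kind, and the four compounds cannot be ranked against one another at this position. No measurement of any other kind is at hand that bears on this result.

For the compounds shown here, still open is whether an amine, a carboxylic acid, a methoxy group or a longer chain on this same aromatic carbon would also stay within the scatter of these four compounds, or would be the first change here to move the number clearly. Also open, on these data alone, is whether hydroxy or a halogen on another carbon of the benzyl ring would read as flat as these exchanges do.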